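Cytotoxicity notes: pyrimidinyl to methyltetrazolyl sulfide swap

The compounds below may be only part of what the source reports. "The series", "measured", "known", "first", "only" and "open" are said of these compounds alone.

Measured so far in a functional assay on C6 cells (Rattus norvegicus) for cytotoxicity, read by MTT assay, with a stated time of 24 h, tested at 100 ug/mL; a higher number here means a weaker effect of the compound at the concentration tested, a lower number a stronger effect:
compound 1 `O=C(CSc1ncccn1)N/N=c1/scc(-c2ccc(F)cc2)n1-c1ccccc1` gives 53.4%
compound 2 `COc1ccc(-c2cs/c(=N/NC(=O)CSc3ncccn3)n2-c2ccccc2)cc1` gives 51.5%
compound 3 `Cc1ccc(-c2cs/c(=N/NC(=O)CSc3ncccn3)n2-c2ccccc2)cc1` gives 45.9%

Compound 3 has the lowest of the three numbers, but its gaps to the others are small: a number 7.5 percentage points lower from compound 1 to compound 3 (within the scatter) and a number 5.6 percentage points lower from compound 2 to compound 3 (within the scatter) both stay within the scatter, as does a number 1.9 percentage points lower from compound 1 to compound 2 (within the scatter). On these numbers the three compounds are not separable.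

Compound 4 `Cc1ccc(-c2cs/c(=N/NC(=O)CSc3nnnn3C)n2-c2ccccc2)cc1` is not yet measured. It differs from compound 3 in one place: 1-methyl-1H-tetrazol-5-yl in place of pyrimidin-2-yl on a sulfur. Among the compounds with values here, all three measured steps concern the substituent on an aromatic carbon; none touches the group on the sulfur, so no measured step bears on this change. Within the data shown here, the expectation for compound 4 therefore rests only on the value of compound 3 and the absence of any sizable step so far; an estimate of no step beyond the scatter is made, a number 1.1 percentage points higher from compound 3 to compound 4 (within the scatter), with a wide range to reflect the missing precedent. Compound 4 is estimated at 47%, between 30% and 65%.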

Compound 4, a percentage reported as activity, at one concentration (the size of the read-out at that concentration, not a potency): 39.7%
Beside the measured number, compound 4's estimate is 7.3 percentage points above it; measured number inside the range.
By their numbers in this assay, from the lowest: compounds 4, 3, 2 and 1 (each within the scatter of the next, the first and the last beyond it).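

Of the steps shown, this is the only one at the sulfur, and in this assay a number 6.2 percentage points lower from compound 3 to compound 4 (within the scatter) leaves the exchange of pyrimidin-2-yl for 1-methyl-1H-tetrazol-5-yl inside the scatter. Within the data shown here, the sulfur position therefore accepts a five-membered aromatic ring with 4 hetero atoms in place of a six-membered one with 2, with no step that can be told apart from repeat variation in this one pair. No available data account for the result.

On these data alone, the tetrazolyl group appears here only with the methyl substituent, so whether the same holds with the fluoro or methoxy substituent remains open. Also open, as far as these compounds go, is how this position responds to a group of another kind on the sulfur, such as a plain alkyl chain or a chain ending in a carboxylic acid.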